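The source may hold more compounds than are shown below. What is called first, only, known or untested is meant among the compounds shown, and "the series" means these compounds.

Series notes, cytotoxicity on the shared core.

Of the compounds shown here, three have numbers so far in a functional assay on HEp-2 cells (Homo sapiens) for cytotoxicity, read by sulforhodamine B assay, with a stated time of 48 h; on this read-out higher numbers stand for weaker inhibition and lower numbers for stronger inhibition. Compound 1 `O=CCN1N=C(c2ccc3ccccc3c2)CC1c1ccccc1[N+](=O)[O-]` gives 3630 nM. Compound 2 `COc1ccc(C2CC(c3ccc4ccccc4c3)=NN2CC=O)cc1O` gives 1020 nM. Compound 3 `COc1ccc(C2CC(c3ccc4ccccc4c3)=NN2CC=O)cc1` gives 3230 nM. On these three numbers compound 3 stands second highest; its nearest neighbour is compound 1, within the scatter, and the one furthest from it is compound 2, beyond the scatter. The measured steps are a 3.6-fold lower number from compound 1 to compound 2 (0.55 log units; beyond the scatter), a 1.1-fold lower number from compound 1 to compound 3 (0.05 log units; within the scatter) and a 3.2-fold higher number from compound 2 to compound 3 (0.50 log units; beyond the scatter): the only moves beyond the scatter involve the hydroxy of compound 2.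

Compound 4 `O=CCN1N=C(c2ccc3ccccc3c2)CC1/C=C/c1ccccc1` is not yet measured. It differs from compound 3 by 2-phenylethenyl in place of 4-methoxyphenyl on a saturated ring carbon. Going by the values given here, no measured step swaps an aryl for an alkenyl group at this carbon, so the nearest guidance is the exchange of one phenyl for another there, where the step from compound 1 to compound 3 stays within the scatter. A step of about a 1.1-fold higher number from compound 3 to compound 4 (0.03 log units; within the scatter) is therefore expected in this assay , with no direction claimed beyond the scatter. Compound 4 is estimated at 3500 nM, in the range 1500 nM to 9000 nM.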

Compound 4, half-maximal inhibitory concentration: 20100 nM
Compound 4: middle estimate off by 5.7-fold (0.76 log units), on the low side, and the stated range ends below it.
By their numbers in this assay, from the lowest: compound 2; then compounds 3 and 1 (each within the scatter of the next); then compound 4.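

Compound 4 is the weakest of the four in this assay, with a 6.2-fold higher number from compound 3 to compound 4 (0.79 log units; beyond the scatter), a 5.5-fold higher number from compound 1 to compound 4 (0.74 log units; beyond the scatter) and a 20-fold higher number from compound 2 to compound 4 (1.29 log units; beyond the scatter). The saturated ring carbon next to the ring nitrogen therefore does not treat all groups of equal size alike: 2-phenylethenyl and 4-methoxyphenyl both hold 8 heavy atoms, yet this exchange moves the number beyond the scatter, whereas 4-methoxyphenyl and 2-nitrophenyl stayed within it. Nothing available here accounts for this step.

From the compounds shown here alone, whether the loss lies with the double bond or with the extra carbons between ring and phenyl stays open, and a plain phenyl or a 2-phenylethyl group at this carbon would help to separate the two. Also open, going by these compounds, is whether a hydroxy on the phenyl of 2-phenylethenyl would lower the number as it does on the aryl of compound 2.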